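Swapping a pyridine for a cyclopropane in a kynurenine inhibitor

The compounds below may be only part of what the source reports. "The series", "measured", "known", "first", "only" and "open" are said of these compounds alone.

Compound 1 `Cc1ccnc([C@@H](C)Oc2cc3oc(=O)n(CCC(=O)O)c3cc2Cl)c1`: 3.98 nM
Compound 2 `O=C(O)CCn1c(=O)oc2cc(OCc3ccccn3)c(Cl)cc21`: 3.16 nM
Compound 3 `Cc1ccc([C@@H](C)Oc2cc3onc(CCC(=O)O)c3cc2Cl)nn1`: 2 nM

In an assay for inhibition of kynurenine 3-monooxygenase (Homo sapiens), read by mass spectrometry, with a stated time of 1 h (a higher number here means a weaker inhibitor, a lower number a stronger inhibitor), compound 2 gives 3.16 nM, the second highest of the three numbers; its gaps to compound 1 and to compound 3 both lie within the usual scatter, so the three compounds read as equally strong.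

Compound 4 `O=C(O)CCn1c(=O)oc2cc(OCC3CC3)c(Cl)cc21` differs from compound 2 in one place: cyclopropyl in place of pyridin-2-yl on a saturated chain carbon bound to an oxygen on an aromatic ring. Within the data shown here, since no step between measured compounds is known for this change, the expectation rests on the change alone, and a modest loss of strength, somewhat beyond the scatter, seems the most likely outcome.

For compound 4 the estimate in this assay is 10 nM (range 3 nM to 40 nM), which would correspond to an expected step of a 3.2-fold higher number from compound 2 to compound 4 (0.50 log units; beyond the scatter).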

Compound 4, half-maximal inhibitory concentration: 10 nM
Compound 4: middle estimate and measured number agree at the digits printed; the measured number falls inside the stated range.
By their numbers in this assay, from the lowest: compounds 3, 2 and 1 (each within the scatter of the next); then compound 4.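

In this assay the change gives a 3.2-fold higher number from compound 2 to compound 4 (0.50 log units; beyond the scatter), so at this position a cyclopropyl, with fewer heavy atoms and no ring nitrogen, costs only modest strength against the pyridin-2-yl. Compound 4, at 10 nM, remains an inhibitor without any aromatic ring on this chain carbon. Nothing available explains the loss in strength.

As far as these compounds go, whether the loss tracks the ring nitrogen or the aromatic ring itself stays open. A phenyl group at this place, holding the aromatic ring without the nitrogen, would separate the two.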